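Methyl for chloro on the aryl ring of an oxadiazole series

The source may hold more compounds than are shown below. What is called first, only, known or untested is meant among the compounds shown, and "the series" means these compounds.

Measured compounds:
compound 1, `Clc1cccc(-c2nnc(C(NCc3ccccc3)c3ccc[nH]3)o2)c1`, 56700 nM
compound 2, `Fc1cc(-c2nnc(C(NCc3ccccc3)c3ccc[nH]3)o2)c(Cl)cc1Cl`, 21700 nM
compound 3, `Cc1ccc(-c2nnc(C(NCc3ccccc3)c3ccc[nH]3)o2)cc1`, 1120000 nM

In a functional assay on MCF7 cells (Homo sapiens) for cytotoxicity, read by MTT assay, with a stated time of 24 h (a lower number here means a stronger inhibitor, a higher number a weaker inhibitor), compound 1 stands second highest of the three numbers. Its nearest neighbour is compound 2, with a 2.6-fold lower number from compound 1 to compound 2 (0.42 log units; beyond the scatter); its furthest is compound 3, with a 20-fold higher number from compound 1 to compound 3 (1.30 log units; beyond the scatter). Compound 3 also lies far from compound 2, with a 52-fold higher number from compound 2 to compound 3 (1.71 log units; beyond the scatter).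

Compound 4, `Cc1cccc(-c2nnc(C(NCc3ccccc3)c3ccc[nH]3)o2)c1`, differs from compound 1 by one change: methyl in place of chloro on an aromatic carbon. Among the measured compounds shown here, no measured step makes exactly this change. The step from compound 1 to compound 3 swaps chloro for methyl as well, but moves the group to another position on the ring, and it was large, toward a higher number. The step from compound 1 to compound 2, which adds halogens, went the other way and was modest. Weighing these, a step toward a higher number in this assay is expected for compound 4, a 4.4-fold higher number from compound 1 to compound 4 (0.64 log units; beyond the scatter), though smaller than the one seen for compound 3. Compound 4 is therefore estimated at 250000 nM, within 60000 nM to 1100000 nM.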

Compound 4, half-maximal inhibitory concentration: 480000 nM
For compound 4 the middle estimate is 1.9-fold (0.28 log units) below the measured one; the measured number falls inside the stated range.
By their numbers in this assay, from the lowest: compound 2; then compound 1; then compound 4; then compound 3.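

In this assay, the swap of 3-chlorophenyl to 3-methylphenyl, with the place on the ring held constant, gives an 8.5-fold higher number from compound 1 to compound 4 (0.93 log units; beyond the scatter), so the change of group alone moves the number beyond the scatter. Moving the methyl gives a 2.3-fold lower number from compound 3 to compound 4 (0.37 log units; beyond the scatter), which shows that its place on the ring also counts, and that the large gap between the 3-chlorophenyl and 4-methylphenyl compounds holds both a change of group and a change of place. With a 22-fold higher number from compound 2 to compound 4 (1.34 log units; beyond the scatter) as well, both methyl compounds among these four carry higher numbers than both halogen-bearing ones, and no compound shown goes against this.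

No measurement shown accounts for these differences. From the compounds shown here alone, it also remains open whether a methoxy group or an amine in this place would fall nearer the chloro or the methyl compounds.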